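The source may hold more compounds than are shown below. What is called first, only, known or untested is meant among the compounds shown, and "the series" means these compounds.

Compound 1, with the structure `O=C1NC(=O)/C(=C/C(c2ccc(-c3ccc4cccc(F)c4c3)[nH]c2=O)C2CC2)O1`, was tested in a functional assay on CHO cells for antagonist activity at prostaglandin E2 receptor EP3 subtype (Homo sapiens), read by cAMP accumulation, with a stated time of 30 min (on this read-out higher numbers stand for weaker inhibition and lower numbers for stronger inhibition), and gives 33 nM. This is the higher of the two numbers in hand, yet it lies close to the other: compound 2, with the structure `CC(C)C(CC1NC(=O)NC1=O)c1ccc(-c2ccc3cccc(F)c3c2)[nH]c1=O`, gives 31 nM in this assay, and the gap between the two falls within the usual scatter of repeated measurements, so the two results cannot be told apart. No single-point change links compound 1 and compound 2, so their values only show that the two compounds behave alike.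

The next compound, compound 3, with the structure `O=C1NC(=O)/C(=C/C(c2ccccc2)c2ccc(-c3ccc4cccc(F)c4c3)[nH]c2=O)O1`, has not yet been measured. It departs from compound 1 in exactly one place:

phenyl in place of cyclopropyl on a saturated chain carbon bound to an aromatic carbon and a double-bonded chain carbon

Nothing measured here shows what a phenyl in place of a cyclopropyl does at this saturated chain carbon, so the expectation rests on compound 1 alone. The step is expected to be small, with no change beyond the scatter: the estimated step is a 1.2-fold higher number from compound 1 to compound 3 (0.08 log units; within the scatter). Compound 3 is therefore expected to give about 40 nM in this assay, with a likely range from 12 nM to 130 nM.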

Compound 3, half-maximal inhibitory concentration in the prostaglandin E2 receptor EP3 subtype assay: 190 nM
The estimate for compound 3 lay 4.8-fold (0.68 log units) below the measured number; measured number outside the range, above it.
By their numbers in the prostaglandin E2 receptor EP3 subtype assay, from the lowest: compounds 2 and 1 (each within the scatter of the next); then compound 3.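

The saturated chain carbon bound to an aromatic carbon and a double-bonded chain carbon is not a free place to make changes: in the prostaglandin E2 receptor EP3 subtype assay, phenyl in place of cyclopropyl gives a 5.8-fold higher number from compound 1 to compound 3 (0.76 log units; beyond the scatter), which means weaker inhibition. The same change moves a second read-out, since in a physicochemical assay for solubility, measured as kinetic solubility, at pH 2 (on this read-out lower numbers stand for lower solubility and higher numbers for higher solubility), compound 1 gives 3850 nM and compound 3 gives 15400 nM. In this one pair, then, phenyl in place of cyclopropyl brings a loss of inhibition together with a gain in solubility, as the measured solubility pair shows: the measured solubility of compound 1, 3850 nM, and of compound 3, 15400 nM, a 4.0-fold higher number (0.60 log units; beyond the scatter)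

As far as these compounds go, whether a methyl, an amine or a carboxylic acid on this carbon could keep the inhibition of compound 1 together with the solubility of compound 3 remains open. From the compounds shown here alone, this step also rests on a single pair of compounds, so it is unknown whether the same change would have the same effects on another core.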